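The source may hold more compounds than are shown below. What is called first, only, known or untested is meant among the compounds shown, and "the series" means these compounds.

Measured in an ADME assay on Vero cells (Chlorocebus sabaeus) for cytotoxicity, read by MTT assay, with a stated time of 48 h; a lower number here means a stronger inhibitor, a higher number a weaker inhibitor:
- Compound 1 `Cc1cccc(C(=O)OC2CCC(CN3CCN(c4cc(=O)c5cc(C(F)(F)F)cc([N+](=O)[O-])c5s4)CC3)CC2)c1`: > 64 ug/mL
- Compound 2 `COc1ccccc1C(=O)OC1CCC(CN2CCN(c3cc(=O)c4cc(C(F)(F)F)cc([N+](=O)[O-])c4s3)CC2)CC1`: > 64 ug/mL
- Compound 3 `O=C(OC1CCC(CN2CCN(c3cc(=O)c4cc(C(F)(F)F)cc([N+](=O)[O-])c4s3)CC2)CC1)c1ccc2c(c1)OCC2`: > 64 ug/mL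

Each of these three entries is a limit of the assay and not a number. In this assay compound 3 gives > 64 ug/mL, which is likewise only a limit.

Compound 4 `COc1ccc(C(=O)OC2CCC(CN3CCN(c4cc(=O)c5cc(C(F)(F)F)cc([N+](=O)[O-])c5s4)CC3)CC2)cc1` carries 4-methoxyphenyl on the carbonyl carbon in place of the group held there by compound 3: a group of 8 heavy atoms (7 carbon, 1 oxygen; one six-membered aromatic ring of carbon only) in place of a group of 9 heavy atoms (8 carbon, 1 oxygen; one five-membered non-aromatic ring with 1 hetero atom, one six-membered aromatic ring of carbon only), on a carbonyl carbon.

Three measured changes at that same carbonyl carbon bear on this one: a step that the two limits leave unreadable from compound 1 to compound 2, a step that the two limits leave unreadable from compound 1 to compound 3 and a step that the two limits leave unreadable from compound 2 to compound 3. No step beyond the scatter is expected in this assay, because the limit of > 64 ug/mL in this assay, at which 3 of the 3 values shown sit, covers compound 1, compound 2 and compound 3 alike. The expected step is a step that the limit leaves unreadable from compound 3 to compound 4. Compound 4 is estimated at 70 ug/mL, with an expected range from 40 ug/mL to 128 ug/mL.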

Compound 4, half-maximal inhibitory concentration: > 64 ug/mL
Compound 4: only a limit was reported; the forecaster's own chance of this, stated with the estimate: 90%; the middle value is on the limit's open side.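

In this assay compound 4 gives > 64 ug/mL, which is a limit and not a number. Among these compounds, no step from compound 1, compound 2 or compound 3 to compound 4 can be read. Whether the groups on the carbonyl carbon differ at all stays open, because all four compounds share one limit: the limit of > 64 ug/mL in this assay, at which 4 of the 4 values shown sit.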